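A thiophene for the phenyl of compound 3

This account rests on a few compounds, and the source may have more. Where it says the series, first, only, none or still open, it means among the compounds named here.

Compound 3 `CCNC(=O)[C@H]1O[C@@H](n2cnc3c(NNC(=O)c4ccccc4)nc(Cl)nc32)[C@H](O)[C@@H]1O` reaches only the limit of an assay on CHO cells for displacement of a labelled ligand from adenosine receptor A1 (Homo sapiens) (on this read-out lower numbers stand for stronger inhibition and higher numbers for weaker inhibition), giving > 5000 nM. Compound 1 `CCNC(=O)[C@H]1O[C@@H](n2cnc3c(NNC(=O)c4cccnc4)ncnc32)[C@H](O)[C@@H]1O` likewise stands at a limit, > 5000 nM in this assay. Compound 2 `CCNC(=O)[C@H]1O[C@@H](n2cnc3c(NNC(=O)c4ccc(C)o4)ncnc32)[C@H](O)[C@@H]1O` gives 700 nM in this assay, and the step of an at least 7.1-fold lower number from compound 1 to compound 2 (0.85 log units; beyond the scatter) shows a heteroaryl ring in place of another ring on the carbonyl carbon lowering the number. Going by the values given here, the change to compound 4 `CCNC(=O)[C@H]1O[C@@H](n2cnc3c(NNC(=O)c4cccs4)nc(Cl)nc32)[C@H](O)[C@@H]1O` is thiophen-2-yl in place of phenyl on a carbonyl carbon, a related exchange at the same place but on a different core, and no measured step covers this exact pair. Two of the three values rest at the limit of > 5000 nM in this assay, at which 2 of the 3 values shown sit, so the starting point is itself uncertain. Compound 4 is therefore expected to show a modest step, an at least 2.0-fold lower number from compound 3 to compound 4 (0.30 log units; that floor lies within the scatter), with an estimate of 2500 nM, between 600 nM and 10000 nM.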

Compound 4, inhibition constant: 737 nM
For compound 4 the middle estimate is 3.4-fold (0.53 log units) above the measured one; measured number inside the range.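

In this assay, thiophen-2-yl in place of phenyl on a carbonyl carbon gives an at least 6.7-fold lower number from compound 3 to compound 4 (0.83 log units; beyond the scatter). A five-membered aromatic ring at this place thus lowers the number on a second core, as 5-methylfuran-2-yl did in an at least 7.1-fold lower number from compound 1 to compound 2 (0.85 log units; beyond the scatter). The true size of the new step remains a floor, since compound 3 stands at a limit: the limit of > 5000 nM in this assay, at which 2 of the 4 values shown sit.

On these data alone, whether a methyl or an amine on the thiophen-2-yl ring would lower the number further stays open. As far as these compounds go, what the chlorine of compound 4 contributes also stays open.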